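Swapping the aryl group on the amide carbonyl

The source may report more compounds than this note shows. Statements on the series, on what has been measured and on what is new or still open speak of the compounds shown alone.

Measured compounds:
Compound 1, `COc1ccc(Cl)cc1C(=O)NCCC1CCN(S(=O)(=O)NC(=O)NC2CCCCC2)CC1`: 39%
Compound 2, `COc1ncccc1C(=O)NCCC1CCN(S(=O)(=O)NC(=O)NC2CCCCC2)CC1`: 22%
Compound 3, `COc1ncc(Cl)cc1C(=O)NCCC1CCN(S(=O)(=O)NC(=O)NC[C@@H]2C[C@@H]3C=C[C@@H]2C3)CC1`: 20%

All three compounds were tested in a functional assay on the whole organism (blood) with Rattus norvegicus as the target, with stated times of 24 h and 1 h, at a dose of 1 mg/kg by the intraperitoneal route; a higher number here means a stronger effect of the compound at the dose given, a lower number a weaker effect. Compound 3 gives the lowest of the three numbers, but its distance to compound 2 lies within the scatter, so no order between those two can be claimed. Compound 1 stands clearly above compound 3, beyond the scatter.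

The new compound 4, `O=C(NC[C@@H]1C[C@@H]2C=C[C@@H]1C2)NS(=O)(=O)N1CCC(CCNC(=O)c2cccc3cccnc23)CC1`, differs from compound 3 in one place: quinolin-8-yl in place of 5-chloro-2-methoxypyridin-3-yl on a carbonyl carbon.

For the measured compounds named here, only one measured step bears on this change, and only loosely. The step of a number 17 percentage points lower from compound 1 to compound 2 (beyond the scatter) also swapped the aryl group on the carbonyl carbon, and it lowered the number by a modest amount. Going by the values given here, compound 4 replaces a ring bearing methoxy and chlorine with a bicyclic quinolin-8-yl, a change that no measured pair mirrors. With compound 3 already near the bottom of the observed range, a further large drop is hard to picture, and nothing in the data supports a rise of the size seen for compound 1.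

Compound 4 is therefore expected to give 22%, within a range of 5% to 45%. The expected step is a number 2 percentage points higher from compound 3 to compound 4 (within the scatter), which would lie within the scatter.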

Compound 4, a percentage reported as activity, at one dose (the size of the read-out at that dose, not a potency): 32%
Compound 4: the middle estimate sits 10 percentage points below what was measured; low and high end bracket the measured number.
By their numbers in this assay, from the lowest: compounds 3, 2, 4 and 1 (each within the scatter of the next, the first and the last beyond it).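

With the rest of the molecule unchanged, placing quinolin-8-yl instead of 5-chloro-2-methoxypyridin-3-yl on the carbonyl carbon gives a number 12 percentage points higher from compound 3 to compound 4 (beyond the scatter) in this assay. Together with the earlier fall of a number 17 percentage points lower from compound 1 to compound 2 (beyond the scatter), this shows that the number at this position can move in either direction when the aryl group is exchanged, and that the entering group reaches a higher number without the methoxy and chlorine of the group it replaces. No measured property is available to account for this rise.

The compounds shown leave open whether quinolin-8-yl would have the same effect alongside the cyclohexyl group found in compound 1 and compound 2, since the step seen here was taken only with the other group at that end of the molecule. They also leave open whether the ring nitrogen of quinolin-8-yl matters to the result, a question that naphthalen-1-yl, with carbon in its place, or an isomeric group such as quinolin-5-yl could address.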